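Trifluoromethyl Added to a Phenyl-Bearing Pyrrole Acid

The source may hold more compounds than are shown below. What is called first, only, known or untested is meant among the compounds shown, and "the series" means these compounds.

Three compounds have numbers in an assay on cells for inhibition of Palmitoleoyl-protein carboxylesterase NOTUM variant C330S (Homo sapiens), read by fluorescence, with a stated time of 40 min; a higher number here means a weaker inhibitor, a lower number a stronger inhibitor. Compound 1 `Cc1[nH]c(C(F)(F)F)cc1C(=O)O` gives 6700 nM, compound 2 `Cc1c(C(=O)O)ccn1-c1ccccc1` gives 3800 nM, and compound 3 `Cc1cc(C(=O)O)c(C)n1-c1cccc(C2CC2)c1` gives 580 nM. Compound 2 stands second highest of the three; its number and that of compound 1 lie within the usual scatter of each other, so nothing separates them, whereas the number of compound 3 is clearly lower, beyond the scatter.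

Compound 4 `Cc1c(C(=O)O)cc(C(F)(F)F)n1-c1ccccc1` has not been measured. It differs from compound 2 in one place: trifluoromethyl in place of hydrogen on an aromatic carbon. Among the compounds with values here, no single-point step between measured compounds exists in this set, so the size of the change can only be guessed from the spread of the three numbers. The account expects that the step in this assay from compound 2 to compound 4 is a modest lowering, a 2.1-fold lower number from compound 2 to compound 4 (0.32 log units; beyond the scatter), possibly no larger than the scatter itself. For compound 4 the estimate in this assay is 1800 nM, expected to fall between 450 nM and 6000 nM.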

Compound 4, half-maximal inhibitory concentration: 22000 nM
Beside the measured number, compound 4's estimate is 12-fold (1.09 log units) below it, and the stated range ends below it.
By their numbers in this assay, from the lowest: compound 3; then compounds 2 and 1 (each within the scatter of the next); then compound 4.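

In this assay, within the data shown here, trifluoromethyl in place of hydrogen on the aromatic carbon next to the ring nitrogen gives the first step that can be read at this position: a 5.8-fold higher number from compound 2 to compound 4 (0.76 log units; beyond the scatter), so this change goes with a weaker inhibitor. Compound 4 carries both trifluoromethyl and phenyl, and the second step, with phenyl in place of hydrogen on the aromatic nitrogen, also goes with a weaker inhibitor: a 3.3-fold higher number from compound 1 to compound 4 (0.52 log units; beyond the scatter), again beyond the scatter. Nothing at hand shows why these two steps come out as they do.

The compounds shown leave open whether a chlorine atom or a nitrile on that same aromatic carbon would follow trifluoromethyl. They also leave open how trifluoromethyl at this position behaves when the phenyl group bears cyclopropyl, as it does in compound 3.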